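The compounds below may be only part of what the source reports. "The series", "measured", "known", "first", "only" and "open" are said of these compounds alone.

Compound 1 `CCCCCCCCNC(=O)[C@@H]1CSC(c2cc(OC)c(OC)c(OC)c2)N1` gives 19600 nM
Compound 2 `CCCCCCCCCCNC(=O)[C@@H]1CSC(c2cc(OC)c(OC)c(OC)c2)N1` gives 2100 nM
Compound 3 `CCCCCCCCCCNC(=O)[C@@H]1CSC(c2ccc(OC)c(OC)c2)N1` gives 6100 nM

All three numbers come from a functional assay on WM164 cells (Homo sapiens) for antiproliferative activity, read by sulforhodamine B assay, with a stated time of 48 h; on this read-out lower numbers stand for stronger inhibition and higher numbers for weaker inhibition. Of these three compounds, compound 3 has the second highest number, so it sits in the middle, with compound 2 lower and compound 1 higher.

Compound 4 `CCCCCCCCCCCCCCCCNC(=O)[C@@H]1CSC(c2ccc(OC)c(OC)c2)N1` has not yet been measured. It keeps the aromatic part of compound 3 and changes only the chain, with hexyl in place of hydrogen on a saturated chain carbon, ten or more bonds along the chain from an amide-type nitrogen.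

Within the data shown here, the best guide is the one measured change on this same chain, a 9.3-fold lower number from compound 1 to compound 2 (0.97 log units; beyond the scatter), which went beyond the scatter. The other measured step, a 2.9-fold higher number from compound 2 to compound 3 (0.46 log units; beyond the scatter), took place on an aromatic carbon and says little about the chain. One step cannot show whether the trend continues as the chain grows further, so the expectation is uncertain. A modest move towards a lower number in this assay seems most likely, possibly smaller than the earlier chain step.

The expected change is a 4.1-fold lower number from compound 3 to compound 4 (0.61 log units; beyond the scatter).

For compound 4 the estimated value is 1500 nM, with an expected range from 400 nM to 7000 nM.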

Compound 4, half-maximal inhibitory concentration: 500 nM
Compound 4: the middle estimate sits 3.0-fold (0.48 log units) above what was measured; low and high end bracket the measured number.
By their numbers in this assay, from the lowest: compound 4; then compound 2; then compound 3; then compound 1.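

Hexyl in place of hydrogen on a saturated chain carbon gives a large gain in this assay, with a 12-fold lower number from compound 3 to compound 4 (1.09 log units; beyond the scatter). Among these compounds, the earlier chain step, a 9.3-fold lower number from compound 1 to compound 2 (0.97 log units; beyond the scatter), was seen only with the methoxy that compound 3 lacks, so the new result shows that a longer chain also lowers the number without that methoxy, and that the trend has not reversed even at this much greater chain length. Nothing available explains why this added carbon chain goes with a lower number in these cells.

The compounds shown do not reveal where this trend ends, since a still longer chain might lower the number further, level off or raise it again, and an amine or a carboxylic acid at the far end of the chain could show whether only a plain carbon chain is accepted there. They also leave open whether putting the missing methoxy back onto compound 4 would lower the number, as the step from compound 3 to its methoxy-bearing partner, compound 2, might suggest.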